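Furanyl for iodo on a second core

This account rests on a few compounds, and the source may have more. Where it says the series, first, only, none or still open, it means among the compounds named here.

Measured compounds:
compound 1 `Cc1ncnc2c1c(I)cn2[C@@H]1O[C@H](CO)[C@@H](O)[C@H]1O` with 12600 nM in a functional assay on CEM-DNR-bulk cells (Homo sapiens), read by MTT assay, with a stated time of 72 h; on this read-out lower numbers stand for stronger inhibition and higher numbers for weaker inhibition
compound 2 `Cc1ncnc2c1c(-c1ccoc1)cn2[C@@H]1O[C@H](CO)[C@@H](O)[C@H]1O` with a limit of > 20000 nM in this assay
compound 3 `Cc1nc(N)c2c(I)cn([C@@H]3O[C@H](CO)[C@@H](O)[C@H]3O)c2n1` with 3480 nM in this assay

Compound 1 carries an iodo group on its core. Compound 2 is made from it by the change (furan-3-yl in place of iodo on an aromatic carbon). That change gives an at least 1.5-fold higher number from compound 1 to compound 2 (0.20 log units; that floor lies within the scatter); the value of compound 2 is only a limit of the assay, as stated in the limit of > 20000 nM in this assay, at which 1 of the 3 values shown sits, so the true size of the step is not known. Compound 3 sits on a different core; the difference between the two cores is not broken down here. In this assay compound 3 gives the lowest number of the two that are given, and its step to compound 1 lies beyond the scatter.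

Compound 4 `Cc1nc(N)c2c(-c3ccoc3)cn([C@@H]3O[C@H](CO)[C@@H](O)[C@H]3O)c2n1` is not yet measured. It is made from compound 3 by the same change, (furan-3-yl in place of iodo on an aromatic carbon), with the same place and groups as before. The expectation for compound 4 rests on the weakening seen in an at least 1.5-fold higher number from compound 1 to compound 2 (0.20 log units; that floor lies within the scatter), so the step of a 3.4-fold higher number from compound 3 to compound 4 (0.54 log units; beyond the scatter) is expected to be at least as large. Compound 4 is therefore estimated at 12000 nM, between 5000 nM and 40000 nM.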

Compound 4, half-maximal inhibitory concentration: > 20000 nM
Compound 4: only a limit was reported (the forecaster's own chance of this, stated with the estimate: 35%); middle value at least 1.6-fold (0.22 log units) from the limit.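

On the second core, furan-3-yl in place of iodo gives an at least 5.7-fold higher number from compound 3 to compound 4 (0.75 log units; beyond the scatter) in this assay, a step read against a limit of the assay. The direction therefore carries over as far as the data go: neither furan-3-yl compound gives a lower number than its iodo counterpart, and on this core the step lies beyond the scatter, whereas on the first core its floor does not. This does not show that the change costs the same or a different amount on the two cores: the same change on two cores in this assay, an at least 1.5-fold higher number (0.20 log units; that floor lies within the scatter) from compound 1 to compound 2 and an at least 5.7-fold higher number (0.75 log units; beyond the scatter) from compound 3 to compound 4; the limit leaves it open whether they differ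

As far as these compounds go, the true values of both furan-3-yl compounds remain open: the limit of > 20000 nM in this assay, at which 2 of the 4 values shown sit. Also open is how an amine, a carboxylic acid or a longer chain in place of iodo would read on either core.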